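Spiro thiophene series: aryl replacement on the benzylic amine

This account rests on a few compounds, and the source may have more. Where it says the series, first, only, none or still open, it means among the compounds named here.

Measured compounds:
compound 1, `CC(C)(C)c1ccc(CN2CCC3(CC2)OCCc2sccc23)cc1` — > 30 mL/min/g
compound 2, `CC(c1ccc(C(F)(F)F)cc1)N1CCC2(CC1)OCCc1sccc12` — 18.1 mL/min/g

In an ADME assay on microsomes from liver (Mus musculus) for metabolic stability, read by LC-MS, using NADPH, with a stated time of 30 min, tested at 0.5 uM (on this read-out lower numbers stand for slow clearance and higher numbers for fast clearance), compound 1 gives only a limit, > 30 mL/min/g. Compound 1 therefore sits at the limit of > 30 mL/min/g in this assay, at which 1 of the 2 values shown sits, and its position among the numbers is known only as that limit. In this assay compound 2 gives 18.1 mL/min/g, a number rather than a limit.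

Compound 3, `c1ccc(Oc2ccc(CN3CCC4(CC3)OCCc3sccc34)cc2)cc1`, is still to be measured. It differs from compound 1 by phenoxy in place of tert-butyl on an aromatic carbon. Going by the values given here, no measured pair shows what such a change does here, and the starting point is a limit, so the size of the step can only be guessed. Fast clearance is expected to remain; the step of an at least 1.2-fold lower number from compound 1 to compound 3 (0.07 log units; that floor lies within the scatter) is estimated to be small, likely within the scatter, with a real chance that only a limit is again reported. Compound 3 is expected to give about 25 mL/min/g, in the range 12 mL/min/g to 50 mL/min/g.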

Compound 3, intrinsic clearance in a liver preparation (reported as CLH), per the amount of preparation that the assay uses: 28.8 mL/min/g
Estimate against measurement, compound 3: 1.2-fold (0.06 log units) below, within the range that was stated.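

Phenoxy in place of tert-butyl on an aromatic carbon gives, in this assay, an at least 1.0-fold lower number from compound 1 to compound 3 (0.01 log units; that floor lies within the scatter). A larger group at this place, bringing a six-membered aromatic ring and a hydrogen-bond acceptor, still leaves fast clearance: compound 3 gives 28.8 mL/min/g. The true size of the step stays unknown, since compound 1 stands at: the limit of > 30 mL/min/g in this assay, at which 1 of the 3 values shown sits.

Going by these compounds alone, whether a carboxylic acid or a nitrile on the same aromatic carbon would bring the number down remains open, with no pair here to show it. Compound 2 differs from compound 1 in more than one place, so the shown compounds also leave open which of those differences matters for clearance.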